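Compound 3: 4-isopropylpiperazin-1-yl in place of diethylamino

A few compounds are considered here, and "the series" means these few. Any claim that something is new, unique, unknown or untested is made for them only; others in the source may bear on it.

Compound 1 (`CCN(CC)Cc1ccc(-c2cnc(N)c(C(=O)NC[C@@](C)(O)C(F)(F)F)n2)cc1`) carries the diethylamino group on the shared core. In a physicochemical assay for solubility, at pH 6.8 (on this read-out lower numbers stand for lower solubility and higher numbers for higher solubility), compound 1 gives > 1000000 nM as its reading, which is a limit of the assay and not a number. Among the compounds with values here, the standing of compound 1 is therefore bounded only, and the series so far reads: the limit of > 1000000 nM in this assay, at which 1 of the 2 values shown sits. Within the data shown here, compound 2 (`CN(C)Cc1ccc(-c2cnc(N)c(C(=O)NC3CCC(O)CC3)n2)cc1`) gives 850000 nM as a measured number in this assay, and no single-place step connects it with compound 1.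

Compound 3 (`CC(C)N1CCN(Cc2ccc(-c3cnc(N)c(C(=O)NC[C@@](C)(O)C(F)(F)F)n3)cc2)CC1`) takes 4-isopropylpiperazin-1-yl in place of diethylamino on a saturated chain carbon bound to an aromatic carbon.

Among the measured compounds shown here, no measured step bears on this exchange, so the expectation rests on very little, with compound 2 at 850000 nM as the only true number nearby. No change beyond the usual scatter is expected in this assay, in either direction. The estimated step of an at least 1.1-fold lower number from compound 1 to compound 3 (0.04 log units; that floor lies within the scatter) is accordingly expected to be small. Compound 3 is estimated at 900000 nM with an expected range from 400000 nM to 1200000 nM in this assay, and a report as a limit alone is quite possible.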

Compound 3, solubility: > 1000000 nM
Compound 3: only a limit was reported; the forecaster's own chance of this, stated with the estimate: 55%; middle value at least 1.1-fold (0.04 log units) away from the limit.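

Compound 1 and compound 3 both stand as limits and not as numbers in this assay, so no step can be read between them: the limit of > 1000000 nM in this assay, at which 2 of the 3 values shown sit.

The compounds shown leave open whether 4-isopropylpiperazin-1-yl in place of diethylamino moves the reading in this assay at all, and if so, in which direction and how far.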